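A Methyl in Place of Trifluoromethyl: What to Expect

The compounds below may be only part of what the source reports. "The series", "measured", "known", "first", "only" and "open" are said of these compounds alone.

Compound 1, `CC[C@H]1CN(c2ncc(C(N)=O)nc2Cl)CCN1C1CCN(C(=O)c2ccc(Cl)nc2N)CC1`, gives 2.5 nM in an in vitro assay on BaF3 cells for displacement of a labelled ligand from C-X-C chemokine receptor type 3 (Homo sapiens); a higher number here means a weaker inhibitor, a lower number a stronger inhibitor.
Compound 2, `CC[C@H]1CN(c2ncc(C(N)=O)nc2C(F)(F)F)CCN1C1CCN(C(=O)c2ccc(Cl)nc2N)CC1`, gives 1.9 nM in this assay.
Compound 3, `CC[C@H]1CN(c2ncc(C(=O)NC3CC3)nc2C(F)(F)F)CCN1C1CCN(C(=O)c2ccc(Cl)nc2N)CC1`, gives 1.8 nM in this assay.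

Compound 2 stands second highest of the three numbers. Its neighbours lie close on both sides: a 1.3-fold lower number from compound 1 to compound 2 (0.12 log units; within the scatter) and a 1.1-fold lower number from compound 2 to compound 3 (0.02 log units; within the scatter), each within the scatter. Compound 4, `CC[C@H]1CN(c2ncc(C(N)=O)nc2C)CCN1C1CCN(C(=O)c2ccc(Cl)nc2N)CC1`, differs from compound 2 by methyl in place of trifluoromethyl on an aromatic carbon. The step that bears on this change is a 1.3-fold lower number from compound 1 to compound 2 (0.12 log units; within the scatter), a change at the same aromatic carbon that left the number essentially unmoved. Compound 4 is therefore expected to show a 1.3-fold higher number from compound 2 to compound 4 (0.12 log units; within the scatter), nothing beyond the scatter. Compound 4 is estimated at 2.5 nM, with a range from 1 nM to 6 nM.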

Compound 4, half-maximal inhibitory concentration: 4 nM
For compound 4 the middle estimate is 1.6-fold (0.20 log units) below the measured one; the measured number falls inside the stated range.
By their numbers in this assay, from the lowest: compounds 3, 2, 1 and 4 (each within the scatter of the next, the first and the last beyond it).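

Of the changes shown at this aromatic carbon, only methyl in place of trifluoromethyl passes beyond the scatter in this assay, with a 2.1-fold higher number from compound 2 to compound 4 (0.32 log units; beyond the scatter) as a modest loss, while methyl in place of chloro gives a 1.6-fold higher number from compound 1 to compound 4 (0.20 log units; within the scatter) and stays within it. The position therefore does respond to its substituent, though chloro cannot be separated from either trifluoromethyl or methyl. No measurement shown accounts for this difference.

As far as these compounds go, whether the methyl step would repeat with the cyclopropyl amide of compound 3 remains open. From the compounds shown here alone, how an amine, a methoxy group or an ethyl group would fare at this carbon also remains open.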